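Lengthening the amine chain: compound 3 to compound 4

The compounds below may be only part of what the source reports. "The series", "measured", "known", "first", "only" and "open" are said of these compounds alone.

Values in a functional assay on NCI-H460 cells (Homo sapiens) for cytotoxicity, read by MTT assay, with a stated time of 72 h; on this read-out lower numbers stand for stronger inhibition and higher numbers for weaker inhibition:
- compound 1 `CNC1=CC(=O)C=C(C(C)(C)C)C1=O`: 23000 nM
- compound 2 `CCNC1=CC(=O)C=C(C(C)(C)C)C1=O`: 14000 nM
- compound 3 `CCNC1=CC(=O)C(C(C)(C)C)=CC1=O`: 65000 nM

Compound 3 has the highest number of the three, lying beyond the scatter from both compound 1 and compound 2. Compound 4 `CCCCNC1=CC(=O)C(C(C)(C)C)=CC1=O` differs from it by ethyl in place of hydrogen on a saturated chain carbon, two bonds along the chain from an amine nitrogen. Going by the values given here, one measured step bears on this, and it was made on the core of compound 1: methyl in place of hydrogen gave a 1.6-fold lower number from compound 1 to compound 2 (0.22 log units; within the scatter). That step is small, so no change beyond the scatter is expected in this assay, with a slight lean towards a lower number. The expected step is a 1.4-fold lower number from compound 3 to compound 4 (0.16 log units; within the scatter). The estimate for compound 4 is 45000 nM, with an expected range of 20000 nM to 85000 nM.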

Compound 4, half-maximal inhibitory concentration: 72000 nM
Compound 4: middle estimate off by 1.6-fold (0.20 log units), on the low side; the range from low to high includes it.
By their numbers in this assay, from the lowest: compounds 2 and 1 (each within the scatter of the next); then compounds 3 and 4 (each within the scatter of the next).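

In this assay, ethyl in place of hydrogen on this chain carbon gives a 1.1-fold higher number from compound 3 to compound 4 (0.04 log units; within the scatter), so ethylamino to butylamino on this core stays within the scatter. The earlier methyl step, a 1.6-fold lower number from compound 1 to compound 2 (0.22 log units; within the scatter), was also within the scatter, on the core of compound 1, so neither core shows a response to the chain changes tested here. No supporting data account for this result. Open, on these data alone, is whether a longer chain, such as hexyl, would behave the same way. Also open, as far as these compounds go, is how a chain carrying an amine or a carboxylic acid would read.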